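Fluoromethyl for methoxymethyl in the low-potency pair

A few compounds are considered here, and "the series" means these few. Any claim that something is new, unique, unknown or untested is made for them only; others in the source may bear on it.

In a functional assay on HeLa cells (Homo sapiens) for cytotoxicity, read by WST assay, with a stated time of 48 h (on this read-out higher numbers stand for weaker inhibition and lower numbers for stronger inhibition), compound 2 `COC[C@H](C)[C@@H](C)C(c1ccc(O)c(OC)c1)c1ccc(O)c(OC)c1` gives 77000 nM and compound 1 `COC[C@H](C)[C@H](C)C(c1ccc(O)c(OC)c1)c1ccc(O)c(OC)c1` gives 72000 nM. These two values lie within the scatter of each other and together form the high end of the three numbers in the series. Compound 3 `CCCCCCCC[C@H](C(C)C)C(c1ccc(O)c(OC)c1)c1ccc(O)c(OC)c1`, which carries a different side chain on the shared core, gives a clearly lower 3100 nM.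

Compound 4 `COc1cc(C(c2ccc(O)c(OC)c2)[C@@H](C)[C@H](C)CF)ccc1O` changes the side chain of compound 2: 2-(fluoromethyl)-1-methylpropyl in place of 2-(methoxymethyl)-1-methylpropyl on a saturated chain carbon bound to two aromatic carbons. In words, this is 2-(fluoromethyl)-1-methylpropyl in place of 2-(methoxymethyl)-1-methylpropyl on a saturated chain carbon bound to two aromatic carbons.

Going by the values given here, the only measured step is a 1.1-fold higher number from compound 1 to compound 2 (0.03 log units; within the scatter), and its scope is set by the fact that compounds 1 and 2 differ only in the configuration as drawn. Among the compounds with values here, that step therefore leaves the exchanged group untouched, and no measured step tests this replacement directly. The value of compound 3 shows that a lower number is possible with another side chain, but it does not give a size for this change. No step beyond the scatter is therefore expected in this assay, with wide uncertainty. The estimated step is a 1.3-fold lower number from compound 2 to compound 4 (0.11 log units; within the scatter). In this assay, the estimate for compound 4 is 60000 nM, with an expected range of 25000 nM to 120000 nM.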

Compound 4, half-maximal inhibitory concentration: 37000 nM
For compound 4 the middle estimate is 1.6-fold (0.21 log units) above the measured one; the measured number falls inside the stated range.
By their numbers in this assay, from the lowest: compound 3; then compounds 4, 1 and 2 (each within the scatter of the next, the first and the last beyond it).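

In this assay, the direct test of this exchange gives a 2.1-fold lower number from compound 2 to compound 4 (0.32 log units; beyond the scatter), a modest step just beyond the scatter, with 2-(fluoromethyl)-1-methylpropyl in place of 2-(methoxymethyl)-1-methylpropyl on a saturated chain carbon bound to two aromatic carbons. Read against the other methoxymethyl compound, the exchange gives a 1.9-fold lower number from compound 1 to compound 4 (0.29 log units; within the scatter), which stays within the scatter, so whether the change is visible at all depends on the reference compound. The two references can be read as a single level, which makes the exchange a borderline change and a small one next to the much lower number of compound 3, whose side chain is of another kind: the fact that compounds 1 and 2 differ only in the configuration as drawn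

Going by these compounds, it remains open whether a hydroxymethyl, an aminomethyl or a carboxylic acid at the same end of the side chain would move the number further in either direction. Compound 4 is also the only fluoromethyl compound among those shown, so the role of configuration in the fluoromethyl side chain remains open too.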